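The source may report more compounds than this note shows. Statements on the series, on what has been measured and on what is new or still open speak of the compounds shown alone.

Among the measured compounds shown here, compound 1 `CNC(=O)N1CCCc2ccc(NC(=O)c3ccc(-c4cnn(C)c4)cc3)cc21` gives 77.4% in a functional assay on MV4-11 cells (Homo sapiens) for antiproliferative activity, with a stated time of 6 days, tested at 1.56 uM (on this read-out higher numbers stand for a stronger effect at the one concentration tested and lower numbers for a weaker effect), the higher of the two numbers measured so far. For the measured compounds named here, compound 2 `CNC(=O)N1CCCc2ccc(NC(=O)c3cccc(-c4ccn(S(C)(=O)=O)n4)c3)cc21` gives 4.03% in this assay, a much weaker result that lies well beyond the usual scatter; compound 2 also differs from compound 1 in more than one place, so no single step links them. Compound 3 `CNC(=O)N1CCCc2ccc(NC(=O)c3ccc(-c4cn[nH]c4)cc3)cc21` has not been measured yet. It differs from compound 1 by hydrogen in place of methyl on an aromatic nitrogen. A small step downward is expected in this assay, a number 9.4 percentage points lower from compound 1 to compound 3 (within the scatter), which is not expected to exceed the scatter. Compound 3 is estimated at 68%, within a range from 40% to 88%.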

Compound 3, a percentage reported as inhibition, at one concentration (the size of the read-out at that concentration, not a potency): 73.5%
Beside the measured number, compound 3's estimate is 5.5 percentage points below it; low and high end bracket the measured number.
By their numbers in this assay, from the lowest: compound 2; then compounds 3 and 1 (each within the scatter of the next).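

Replacing 1-methyl-1H-pyrazol-4-yl with 1H-pyrazol-4-yl gives a number 3.9 percentage points lower from compound 1 to compound 3 (within the scatter) in this assay and so leaves the effect within the scatter. On the core of compound 1, this aromatic nitrogen therefore keeps its effect in this assay with either methyl or hydrogen on it. Nothing available here explains this result. As far as these compounds go, whether an ethyl group, a longer chain or an amine-bearing chain on this nitrogen would also keep the effect remains open. So does whether the same swap behaves alike on other cores.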